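The source may hold more compounds than are shown below. What is called first, only, known or untested is meant among the compounds shown, and "the series" means these compounds.

Measured compounds:
compound 1 `C=CC(=O)Nc1cccc(-n2c(=O)cc(C)c3cnc(Nc4ccccc4Nc4nc5c(s4)CN(C)CC5)nc32)c1`: 888 ng.h/mL
compound 2 `C=CC(=O)Nc1cc(-n2c(=O)cc(C)c3cnc(Nc4ccc(N5CCN(C)C(C)C5)cc4OC)nc32)cc(C(F)(F)F)c1`: 398 ng.h/mL

Two compounds of the series have been run in an ADME assay on the whole organism (strain Sprague-Dawley) for pharmacokinetics, with Rattus norvegicus as the target, read by LC-MS, at a dose of 5 mg/kg by the intravenous route; a lower number here means less compound in the circulation, a higher number more compound in the circulation at the dose given. Compound 1 `C=CC(=O)Nc1cccc(-n2c(=O)cc(C)c3cnc(Nc4ccccc4Nc4nc5c(s4)CN(C)CC5)nc32)c1` gives 888 ng.h/mL. Compound 2 `C=CC(=O)Nc1cc(-n2c(=O)cc(C)c3cnc(Nc4ccc(N5CCN(C)C(C)C5)cc4OC)nc32)cc(C(F)(F)F)c1` gives 398 ng.h/mL, the lower of the two numbers; the gap to compound 1 lies beyond the scatter of repeated measurements, so compound 2 stands below compound 1 on what has been measured. Among the compounds with values here, the two compounds differ in more than one place, so no single step between them can be read from their values.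

Compound 3 `C=CC(=O)Nc1cccc(-n2c(=O)cc(C)c3cnc(Nc4ccc(N5CCN(C)C(C)C5)cc4OC)nc32)c1` is not yet measured. It differs from compound 2 in one place: hydrogen in place of trifluoromethyl on an aromatic carbon. Compound 1 likewise carries no trifluoromethyl, but it differs from compound 2 elsewhere as well, so the value of compound 1 cannot be charged to that group alone. A step from compound 2 to compound 3 within the scatter is expected, leaning upward if anywhere, because compound 1 gives 888 ng.h/mL. Compound 3 is expected at 550 ng.h/mL, with a range of 250 ng.h/mL to 1200 ng.h/mL. The expected step is a 1.4-fold higher number from compound 2 to compound 3 (0.14 log units; within the scatter).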

Compound 3, area under the concentration-time curve: 433 ng.h/mL
For compound 3 the middle estimate is 1.3-fold (0.10 log units) above the measured one; the measured number falls inside the stated range.
By their numbers in this assay, from the lowest: compounds 2 and 3 (each within the scatter of the next); then compound 1.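

In this assay, hydrogen in place of trifluoromethyl on the aromatic carbon, meta to the (vinylcarbonyl)amino group, gives a 1.1-fold higher number from compound 2 to compound 3 (0.04 log units; within the scatter). Within the data shown here, this is the one step that isolates a single place, and it puts compound 2 and compound 3 within the scatter of each other: at this position, in this structural setting, the read-out does not separate the trifluoromethyl group and its 4 heavy atoms from hydrogen. No accompanying measurement bears on why the two compounds read alike.

Only hydrogen and trifluoromethyl are shown at this position, so whether a chlorine, a methoxy group, a nitrile or a small amine would also stay within the scatter remains open. The step also rests on a single pair sharing the rest of its structure, so whether the same holds with the different substituent on the core of compound 1 cannot be read from these compounds.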